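The compounds below may be only part of what the source reports. "The series", "measured", "known", "first", "only" and "open" are said of these compounds alone.

Compound 1 `CCN(CC)c1ccc(N2C(=O)CSC2c2cccc(C(=O)NCCCCc3ccccc3)c2)cc1` gives in a functional assay on HOS-TE85 cells (Homo sapiens) for inhibition, read by CCK-8 assay, with a stated time of 72 h (a higher number here means a weaker inhibitor, a lower number a stronger inhibitor), only a limit, > 1000 nM; this is the limit of > 1000 nM in this assay, at which 1 of the 3 values shown sits, so its place on the scale is not fixed. Going by the values given here, compound 2 `O=C(NCCCCn1cccn1)c1cccc(C2SCC(=O)N2c2ccccn2)c1` gives 60.3 nM in this assay, and compound 3 `Cc1ccnc(N2C(=O)CSC2c2cccc(C(=O)NCCCCn3cccn3)c2)c1` gives 19.6 nM; the one step measured between compounds that differ in a single place is a 3.1-fold lower number from compound 2 to compound 3 (0.49 log units; beyond the scatter). Compound 4 `O=C(NCCCCc1ccccc1)c1cccc(C2SCC(=O)N2c2ccccc2F)c1` differs from compound 1 by 2-fluorophenyl in place of 4-(diethylamino)phenyl on an amide-type nitrogen in a ring. Among the compounds with values here, no measured step concerns the group on the amide-type nitrogen in the ring, so the methyl step offers no guide to size or direction here, and for compound 1 itself only a limit is known. Compound 4 is therefore estimated at 300 nM, with a range from 60 nM to 2000 nM, an expected step of an at least 3.3-fold lower number from compound 1 to compound 4 (0.52 log units; beyond the scatter).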

Compound 4, half-maximal inhibitory concentration: 34.1 nM
For compound 4 the middle estimate is 8.8-fold (0.94 log units) above the measured one; the whole stated range lies above it.
By their numbers in this assay, from the lowest: compounds 3, 4 and 2 (each within the scatter of the next, the first and the last beyond it). At a limit, above all of these: compound 1.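

At the amide-type nitrogen in the ring, 2-fluorophenyl in place of 4-(diethylamino)phenyl gives an at least 29-fold lower number from compound 1 to compound 4 (1.46 log units; beyond the scatter), so in this assay this position can carry a large change, which the methyl step did not show. The change removes the diethylamino group and adds fluorine in one step, so the two effects cannot be separated. The step is only a bound, since compound 1 stands at a limit: the limit of > 1000 nM in this assay, at which 1 of the 4 values shown sits.

Still open, on these data alone, is how an unsubstituted phenyl would read at this position. As far as these compounds go, whether a dimethylamino group is tolerated there also remains unknown.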